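Substituent swap on a ring nitrogen of a weak sigma-2 ligand

This account rests on a few compounds, and the source may have more. Where it says the series, first, only, none or still open, it means among the compounds named here.

Of the compounds shown here, two have been measured in an assay on membranes from liver for displacement of a labelled ligand from Sigma intracellular receptor 2 (Rattus norvegicus), read by scintillation counting, with a stated time of 120 min; on this read-out lower numbers stand for stronger inhibition and higher numbers for weaker inhibition. Compound 1 `Cc1cccc2sc(NC(=O)CCN3CCN(CC4CCCO4)CC3)nc12` gives 5000 nM, and compound 2 `Cc1cccc2sc(NC(=O)CCN3CCN(C4CCN(C)CC4)CC3)nc12` gives 3600 nM. The two numbers lie close together: a 1.4-fold lower number from compound 1 to compound 2 (0.14 log units; within the scatter). On the numbers shown, compound 2 holds the lowest value, with compound 1 as its only neighbour, and the gap between them does not exceed the scatter, so no order between the two can be claimed.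

Compound 3 `Cc1cccc2sc(NC(=O)CCN3CCN(c4ccncc4)CC3)nc12` has not been measured. It differs from compound 2 in one place: pyridin-4-yl in place of 1-methylpiperidin-4-yl on an amine nitrogen in a ring. For the measured compounds named here, the only measured step, from compound 1 to compound 2, also exchanged a group on that same ring nitrogen and stayed within the scatter; beyond that, nothing in the data speaks to this particular exchange. The expectation is therefore that the step from compound 2 to compound 3 stays small, a 1.1-fold higher number from compound 2 to compound 3 (0.05 log units; within the scatter), without a clear direction. Compound 3 is estimated to give 4000 nM in this assay, within a range from 1500 nM to 12000 nM.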

Compound 3, inhibition constant: 1700 nM
The estimate for compound 3 lay 2.4-fold (0.37 log units) above the measured number; the range from low to high includes it.
By their numbers in this assay, from the lowest: compound 3; then compounds 2 and 1 (each within the scatter of the next).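

For the compounds shown here, at the amine nitrogen in a ring, the exchange of 1-methylpiperidin-4-yl for pyridin-4-yl gives the first step at this site that lies beyond the scatter in this assay: a 2.1-fold lower number from compound 2 to compound 3 (0.33 log units; beyond the scatter). The same group in place of (oxolan-2-yl)methyl gives a step of the same modest kind (a 2.9-fold lower number from compound 1 to compound 3 (0.47 log units; beyond the scatter)), so this nitrogen now shows some response to its substituent, which the earlier exchange (a 1.4-fold lower number from compound 1 to compound 2 (0.14 log units; within the scatter)) could not show. The entering group carries a six-membered aromatic ring where the leaving group carries a non-aromatic one, with equal counts of hydrogen-bond donors and acceptors, but no measurement at hand accounts for the lower number.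

The compounds shown leave open whether the lower number goes with the aromatic ring itself or with the place of its nitrogen, which a phenyl group and a pyridin-3-yl group on the same nitrogen would help to separate. They also leave open whether a substituent on the pyridine ring, such as a methoxy group or a chlorine atom, would carry the number further in either direction.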